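A Pentyl Chain in Place of Fluoro

The source may report more compounds than this note shows. Statements on the series, on what has been measured and on what is new or still open speak of the compounds shown alone.

In a functional assay on MDA-MB-231 cells (Homo sapiens) for antiproliferative activity, with a stated time of 4 days (a higher number here means a weaker inhibitor, a lower number a stronger inhibitor), compound 1 (`O=Cc1c(-c2ccccc2)[nH]c2ccccc12`) gives 420 nM and compound 2 (`COc1ccc(-c2[nH]c3ccc(OC)cc3c2C=O)cc1`) gives 260 nM on the same cells. Compound 3 (`COc1ccc(-c2[nH]c3ccc(F)cc3c2C=C(C#N)C#N)cc1`) records 400 nM in this assay and so lies within the scatter of both compound 1 and compound 2.

Compound 4 (`CCCCCc1ccc2[nH]c(-c3ccc(OC)cc3)c(C=C(C#N)C#N)c2c1`) departs from compound 3 in a single place (pentyl in place of fluoro on an aromatic carbon). This exchange sits on a six-membered aromatic ring of carbon only, part of a fused or bridged system of two rings.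

Going by the values given here, no two measured compounds differ in just one place, so the data contain no direct precedent for this exchange in this assay. The measured compounds differ in several places, yet compound 2 at 260 nM and compound 3 at 400 nM remain within the scatter of each other, which gives no reason to expect a large loss. A moderate step toward a lower number, meaning a stronger inhibitor, is expected, although a result within the scatter remains possible. The expected size of the change is a 3.3-fold lower number from compound 3 to compound 4 (0.52 log units; beyond the scatter) by this estimate. For compound 4 an estimate of 120 nM is expected, with a range of 20 nM to 600 nM around it.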

Compound 4, half-maximal inhibitory concentration: 42 nM
For compound 4 the middle estimate is 2.9-fold (0.46 log units) above the measured one; low and high end bracket the measured number.
By their numbers in this assay, from the lowest: compound 4; then compounds 2, 3 and 1 (each within the scatter of the next).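

In this assay, going by these compounds alone, pentyl in place of fluoro gives a 9.5-fold lower number from compound 3 to compound 4 (0.98 log units; beyond the scatter), the only change in these data that can be read on its own, since the earlier compounds differ from one another in several places. It shows that this aromatic carbon, on a six-membered aromatic ring of carbon only that is part of a fused or bridged system of two rings, tolerates a chain of 5 carbon atoms in place of a single fluorine, and that the exchange brings a step toward a stronger inhibitor beyond the scatter rather than a loss. The data hold no measurement that explains this step, so its cause stays unknown.

A single exchange cannot tell whether the number follows chain length, so methyl, propyl or a longer chain such as octyl at this carbon, or a branched chain such as isopentyl, would be needed to define the trend. Going by these compounds, it also remains open whether a chain ending in an amine or a carboxylic acid would hold the step, and whether pentyl would have a similar effect on a compound that carries the aldehyde of compound 2 in place of the dinitrile-bearing side chain of compound 4.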